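Swapping Hydroxy for Methyl on Two Related Cores

The compounds below may be only part of what the source reports. "The series", "measured", "known", "first", "only" and "open" are said of these compounds alone.

Three compounds were measured in a functional assay on HepG2 cells (Homo sapiens) for inhibition, read by MTT assay, with a stated time of 72 h; on this read-out lower numbers stand for stronger inhibition and higher numbers for weaker inhibition. Compound 1 `O=c1cc(Cn2cc(-n3ccc4cc(I)ccc43)nn2)c2ccc(O)cc2o1` gives 8570 nM in this assay. Compound 2 `Cc1ccc2c(Cn3cc(-n4ccc5cc(I)ccc54)nn3)cc(=O)oc2c1` carries methyl in place of hydroxy on an aromatic carbon, and in this assay compound 2 gives 38100 nM. That change produced a 4.4-fold higher number from compound 1 to compound 2 (0.65 log units; beyond the scatter). Compound 3 `Cn1c(-c2cn(Cc3cc(=O)oc4cc(O)ccc34)nn2)nc2ccccc21` is built on another core; the difference between the two cores is not broken down here. In this assay compound 3 gives 70700 nM, the highest of the three numbers, although its gap to compound 2 lies within the scatter while its gap to compound 1 lies beyond it.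

Compound 4 `Cc1ccc2c(Cn3cc(-c4nc5ccccc5n4C)nn3)cc(=O)oc2c1` has not yet been measured. It differs from compound 3 by methyl in place of hydroxy on an aromatic carbon, the same change as that between compound 1 and compound 2. For the measured compounds named here, with only one measured instance to go on, the expected step is a 3.5-fold higher number from compound 3 to compound 4 (0.55 log units; beyond the scatter), resting on a 4.4-fold higher number from compound 1 to compound 2 (0.65 log units; beyond the scatter). Going by the values given here, because compound 3 already gives 70700 nM, the number expected for compound 4 would lie above every value measured so far. Compound 4 is expected to give 250000 nM, most likely between 80000 nM and 800000 nM.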

Compound 4, half-maximal inhibitory concentration: 900 nM
For compound 4 the middle estimate is 280-fold (2.44 log units) above the measured one; the whole stated range lies above it.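

In this assay, methyl in place of hydroxy on an aromatic carbon gave a 79-fold lower number from compound 3 to compound 4 (1.90 log units; beyond the scatter), so the change that had weakened inhibition on the core of compound 1 strengthened it on the core of compound 3. The two steps therefore differ in direction as well as in size: the same change on two cores in this assay, a 4.4-fold higher number (0.65 log units; beyond the scatter) from compound 1 to compound 2 and a 79-fold lower number (1.90 log units; beyond the scatter) from compound 3 to compound 4, 350-fold (2.54 log units) apart, beyond the scatter of two such steps. For the compounds shown here, this shows that, in this series, the step measured on one core cannot be carried over to the other, but it does not show what in the two cores separates the outcomes, and with only two pairs it sets no rule for any further core.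

The compounds shown leave open whether another group on that aromatic carbon, such as methoxy or an amine, would follow the hydroxy or the methyl result on each core. They also leave open whether the reversal seen in this assay would appear on other cell lines.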